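Tolerated Concentration After Changing the Ether Side Chain

The source may report more compounds than this note shows. Statements on the series, on what has been measured and on what is new or still open speak of the compounds shown alone.

Compound 1 `O=S1(=O)C=C(OCc2ccccc2)C(Cc2ccccc2)(Cc2ccccc2)O1`: 200000 nM
Compound 2 `CCC1(Cc2ccccc2)OS(=O)(=O)C=C1OCc1ccc(C)cc1`: >= 16000 nM (a limit of the assay)
Compound 3 `CCCC1(Cc2ccccc2)OS(=O)(=O)C=C1OCc1ccccc1`: >= 400000 nM (a limit of the assay)

In an ADME assay on HEL cells (Homo sapiens) for cytotoxicity, with a stated time of 3 days (a higher number here means that more compound is tolerated, a lower number that less compound is tolerated), compound 1 gives 200000 nM. For compound 2 this assay reports only a limit, >= 16000 nM, which is the limit of >= 16000 nM in this assay, at which 1 of the 3 values shown sits. For compound 3 likewise only a limit is reported, >= 400000 nM, which is the limit of >= 400000 nM in this assay, at which 1 of the 3 values shown sits. Among the measured compounds shown here, the one measured step in this assay, an at least 2.0-fold higher number from compound 1 to compound 3 (0.30 log units; that floor lies within the scatter), alters a different place from the one at issue here. Compound 4 `CCC1(Cc2ccccc2)OS(=O)(=O)C=C1OCCCCc1ccccc1` differs from compound 2 as follows: 3-phenylpropyl in place of 4-methylphenyl on a saturated chain carbon bound to an oxygen on an unsaturated carbon. For the measured compounds named here, no measured step touches this place, so nothing points to a shift in either direction, and compound 2 itself is known only as a limit. Compound 4 is therefore expected to give about 100000 nM, a step that the limit leaves unreadable from compound 2 to compound 4, estimated to lie between 16000 nM and 400000 nM.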

Compound 4, minimum cytotoxic concentration: >= 20000 nM
Compound 4: a limit, no number; the forecaster's own chance of this, stated with the estimate: 60%; the middle value does not contradict the limit.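

Compound 2 and compound 4 are each reported only as a limit in this assay, so the step between them cannot be read. The compounds shown leave open whether 3-phenylpropyl in place of 4-methylphenyl changes the tolerated concentration, and in which direction.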